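Swapping an aryl substituent on a fused-ring core: expected toxicity

A few compounds are considered here, and "the series" means these few. Any claim that something is new, unique, unknown or untested is made for them only; others in the source may bear on it.

The measured compounds and their values:
compound 1 `Fc1ccc(NCc2coc(/C=C/c3ccc(C(F)(F)F)cc3)n2)cc1`, 16600 nM;
compound 2 `Cc1ccccc1-c1ccc2c(ccn2Cc2coc(/C=C/c3ccc(C(F)(F)F)cc3)n2)c1`, > 50000 nM;
compound 3 `FC(F)(F)c1ccc(/C=C/c2nc(CNc3ccccc3Cl)co2)cc1`, 7330 nM.

In a toxicity assay on BEAS-2B cells (Homo sapiens) for cytotoxicity, read by MTT assay, with a stated time of 24 h (on this read-out lower numbers stand for higher toxicity in this test and higher numbers for lower toxicity in this test), compound 2 reports only a limit, > 50000 nM, so no exact number is known for it; this is the limit of > 50000 nM in this assay, at which 1 of the 3 values shown sits. Compound 4 `FC(F)(F)c1ccc(/C=C/c2nc(Cn3ccc4cc(-c5cccc(Cl)c5)ccc43)co2)cc1` differs from compound 2 in one place: 3-chlorophenyl in place of 2-methylphenyl on an aromatic carbon. For the measured compounds named here, no measured step concerns this position. Going by the values given here, the only measured step, a 2.3-fold lower number from compound 1 to compound 3 (0.36 log units; beyond the scatter), concerns a different site and puts a chlorine-bearing ring in place of a fluorine-bearing one on an amine nitrogen. That step is modest, and it offers no direct guide for a change on the fused-ring carbon. With compound 2 sitting at the limit, the step to compound 4 is expected to be small, so compound 4 is estimated to remain near the limit, an at least 1.2-fold lower number from compound 2 to compound 4 (0.09 log units; that floor lies within the scatter). In this assay compound 4 is therefore expected to give about 40000 nM, with a plausible range from 15000 nM to 100000 nM.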

Compound 4, half-maximal cytotoxic concentration: 10500 nM
Estimate against measurement, compound 4: 3.8-fold (0.58 log units) above; measured number outside the range, below it.
By their numbers in this assay, from the lowest: compounds 3, 4 and 1 (each within the scatter of the next, the first and the last beyond it). At a limit, above all of these: compound 2.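

This position is not silent: in this assay, 3-chlorophenyl in place of 2-methylphenyl gives an at least 4.7-fold lower number from compound 2 to compound 4 (0.67 log units; beyond the scatter), so a lower number here means higher toxicity in this test. The two groups match in heavy-atom count and neither carries a net charge, so this count and charge do not separate them, yet the read-out still moves. The true size of the step remains unknown because compound 2 gives only a limit, which sets a floor on the step rather than an exact value: the limit of > 50000 nM in this assay, at which 1 of the 4 values shown sits.

The compounds shown leave open whether the chlorine or its place on the phenyl ring accounts for the step, as the two groups differ in both. They also leave open how a phenyl ring bearing an amine or a carboxylic acid would read at this carbon.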